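Aryl ketone series on the shared core: the aldehyde variant

A few compounds are considered here, and "the series" means these few. Any claim that something is new, unique, unknown or untested is made for them only; others in the source may bear on it.

Compound 1 `COc1ccc(C(=O)c2ccc3c(c2)C(n2ccccc2=O)=CC(C)(C)O3)cc1` carries an aryl ketone on the shared core; in a functional assay (aorta) with Rattus norvegicus as the target (a lower number here means a less potent compound, a higher number a more potent compound, by a factor of ten per unit of this negative logarithm), compound 1 gives 6.15. Compound 2 `CC1(C)C=C(n2ccccc2=O)c2cc(C(=O)c3ccccc3F)ccc2O1` gives 7.08, and compound 3 `CC1(C)C=C(n2ccccc2=O)c2cc(C(=O)c3c(F)cccc3F)ccc2O1` gives 6.97. Compound 3 thus sits together with compound 2, with a number 0.11 log units lower from compound 2 to compound 3 (within the scatter), and well clear of compound 1, with a number 0.82 log units higher from compound 1 to compound 3 (beyond the scatter). Compound 4 `CC1(C)C=C(n2ccccc2=O)c2cc(C=O)ccc2O1` differs from compound 3 in one place: hydrogen in place of 2,6-difluorophenyl on a carbonyl carbon. Among the compounds with values here, the measured steps, a number 0.93 log units higher from compound 1 to compound 2 (beyond the scatter) and a number 0.82 log units higher from compound 1 to compound 3 (beyond the scatter), concern only one aryl ring traded for another; no measured step removes the ring, so there is no direct guide. A loss is expected, estimated as a number 0.97 log units lower from compound 3 to compound 4 (beyond the scatter), with wide uncertainty. Compound 4 is therefore expected near 6, within 5.2 to 6.8.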

Compound 4, logarithm of the reciprocal of the active concentration, log(1/C): 6.91
The estimate for compound 4 lay 0.91 log units below the measured number; the whole stated range lies below it.
By their numbers in this assay, from the lowest: compound 1; then compounds 4, 3 and 2 (each within the scatter of the next).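

For this assay an aryl ring on the carbonyl carbon proves dispensable in this set: hydrogen in place of 2,6-difluorophenyl gives a number 0.06 log units lower from compound 3 to compound 4 (within the scatter) and hydrogen in place of 2-fluorophenyl gives a number 0.17 log units lower from compound 2 to compound 4 (within the scatter) in the same assay. Only the 4-methoxyphenyl ketone stands apart, with a number 0.76 log units higher from compound 1 to compound 4 (beyond the scatter) on the same change, so the aldehyde groups with the two fluorinated ketones and not with compound 1. No measured evidence bearing on the reason accompanies these compounds.

From the compounds shown here alone, whether a methyl group, an amine or a longer chain on the carbonyl carbon would keep the number in this assay remains open.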